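Swapping tert-butyl for trifluoromethyl on the benzyl ring

The source may report more compounds than this note shows. Statements on the series, on what has been measured and on what is new or still open speak of the compounds shown alone.

Measured compounds:
compound 1, `CC(C)(C)c1ccc(CNCCCNS(=O)(=O)c2cc(C(F)(F)F)cc(C(F)(F)F)c2)cc1`, 2100 nM
compound 2, `O=S(=O)(NCCNCc1ccc(-c2ccccc2)cc1)c1cc(C(F)(F)F)cc(C(F)(F)F)c1`, 2400 nM

Two sulfonamides have been measured in a functional assay on Capan-2 cells (Homo sapiens) for inhibition, read by MTT assay, with a stated time of 72 h; a lower number here means a stronger inhibitor of growth, a higher number a weaker inhibitor of growth. Compound 1 gives 2100 nM, the lower of the two numbers. Compound 2 gives 2400 nM, which lies within the scatter of compound 1, so the two cannot be told apart on these data.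

Compound 3, `O=S(=O)(NCCCNCc1ccc(C(F)(F)F)cc1)c1cc(C(F)(F)F)cc(C(F)(F)F)c1`, has not yet been measured. It differs from compound 1 in one place: trifluoromethyl in place of tert-butyl on an aromatic carbon. The rest of the molecule, the sulfonamide, the three-carbon chain and the secondary amine, is kept.

Among the compounds with values here, no step between measured compounds speaks to this change, and compound 2 carries a different group at the same place with a number close to that of compound 1. On that basis a small step is expected from compound 1 to compound 3 in this assay, of the size a 1.3-fold higher number from compound 1 to compound 3 (0.12 log units; within the scatter), most likely within the scatter and, if anything, toward a higher number. Compound 3 is therefore estimated at 2800 nM, with a range from 1200 nM to 7000 nM.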

Compound 3, concentration for 50% growth inhibition: 2000 nM
Compound 3: middle estimate off by 1.4-fold (0.15 log units), on the high side; the range from low to high includes it.
By their numbers in this assay, from the lowest: compounds 3, 1 and 2 (each within the scatter of the next).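

In this assay, the exchange from 4-(tert-butyl)benzyl to 4-(trifluoromethyl)benzyl gives a 1.1-fold lower number from compound 1 to compound 3 (0.02 log units; within the scatter), so on these data the two groups cannot be told apart at this place on the aromatic ring, though the atoms that make them up differ: four carbon in one, one carbon and three fluorine in the other. Within the data shown here, this is the first comparison that isolates this position, as compound 1 and compound 2 differ in more than one place and could not separate the group from the rest of the molecule. Nothing measured here bears on why the two groups read alike in these cells.

As far as these compounds go, it remains open whether a group of another kind at this place, such as a methoxy, an amine or a carboxylic acid, or a bare hydrogen, would move the number beyond the scatter. From the compounds shown here alone, it is equally open whether the exchange of tert-butyl for trifluoromethyl would read the same on a longer chain between the sulfonamide and the secondary amine.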